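Three Sulfonamides at the Limit, a Fourth Expected There

A few compounds are considered here, and "the series" means these few. Any claim that something is new, unique, unknown or untested is made for them only; others in the source may bear on it.

In an assay on isolated protein for inhibition of malate dehydrogenase, mitochondrial (Sus scrofa), with stated times of 45 min and 30 min (a higher number here means a weaker inhibitor, a lower number a stronger inhibitor), compound 1 `O=S(=O)(Nc1ccc(-c2nc3ccccc3o2)cc1)c1ccccc1Cl` gives only the limit > 63000 nM. Compound 2 `Cc1ccccc1S(=O)(=O)Nc1ccc2oc(-c3ccccc3)nc2c1` likewise reaches only the limit > 63000 nM in this assay. Compound 3 `O=S(=O)(Nc1ccc(-c2nc3ccccc3o2)cc1)c1ccc(F)c(C(F)(F)F)c1` also stops at the limit > 63000 nM. Compound 2 thus stands where every value shown stands, at the limit (the limit of > 63000 nM in this assay, at which 3 of the 3 values shown sit). Compound 4 `O=S(=O)(Nc1ccc2oc(-c3ccccc3)nc2c1)c1ccccc1Cl` differs from compound 2 by chloro in place of methyl on an aromatic carbon, read one bond further out as 2-methylphenyl to 2-chlorophenyl. Going by the values given here, no measured pair shows this change, and the three limits give no ground for expecting a step beyond the scatter in either direction. The step expected in this assay is therefore a step that the limit leaves unreadable from compound 2 to compound 4, an estimate only. Compound 4 is expected to give about 80000 nM, most likely again only as a limit, within 40000 nM to 200000 nM.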

Compound 4, half-maximal inhibitory concentration: > 63000 nM
Compound 4 was reported as a limit; the forecaster's own chance of this, stated with the estimate: 85%; the middle value does not contradict the limit.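

Compound 2 and compound 4 both stop at a limit of the assay, so no step can be read between them: the limit of > 63000 nM in this assay, at which 4 of the 4 values shown sit. The compounds shown leave open whether chloro in place of methyl changes anything in this assay, and how strongly any of them inhibits.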